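Second methyl on the chain carbon of compound 2

This account rests on a few compounds, and the source may have more. Where it says the series, first, only, none or still open, it means among the compounds named here.

Measured compounds:
compound 1, `CCN(Cc1cccs1)C(=O)COc1ccc(C)cc1`, in an assay on HEK293 cells for agonist activity at transient receptor potential cation channel subfamily M member 8 (Homo sapiens), read by fluorescence and calcium flux, with a stated time of 15 min (a higher number here means that more compound is needed for the effect, a lower number that less compound is needed), gives 8 nM.
compound 2, `CCN(Cc1cccs1)C(=O)C(C)Oc1ccc(C)cc1`, in this assay gives 889 nM.
compound 3, `CCN(Cc1cccs1)C(=O)COc1ccc(Cl)cc1`, in this assay gives 39 nM.

Compound 2 stands highest of the three numbers in this assay; the values of compound 3 and of compound 1 both lie well below it, with compound 1 the further of the two, and both gaps are beyond the scatter.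

Compound 4 is `CCN(Cc1cccs1)C(=O)C(C)(C)Oc1ccc(C)cc1`. It differs from compound 2 by methyl in place of hydrogen on a saturated chain carbon bound to a carbonyl carbon, an oxygen on an aromatic ring and a saturated chain carbon. The step that bears on this change is the one where the first methyl entered the same chain carbon: a 110-fold higher number from compound 1 to compound 2 (2.05 log units; beyond the scatter), a large rise. The chloro step, a 4.9-fold higher number from compound 1 to compound 3 (0.69 log units; beyond the scatter), concerns a different site and is only modest; it does not speak to the change in hand. A second methyl on a carbon that already carries one is expected to push the number up again, though a repeat of the full first increase is not assumed; the expected step is a 5.6-fold higher number from compound 2 to compound 4 (0.75 log units; beyond the scatter). Compound 4 is therefore expected to give about 5000 nM in this assay, within a range of 1500 nM to 20000 nM.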

Compound 4, half-maximal effective concentration: 11000 nM
The estimate for compound 4 lay 2.2-fold (0.34 log units) below the measured number; the measured number falls inside the stated range.
By their numbers in this assay, from the lowest: compound 1; then compound 3; then compound 2; then compound 4.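

In this assay the second methyl on the chain carbon again raises the number, a 12-fold higher number from compound 2 to compound 4 (1.09 log units; beyond the scatter), so the rise seen with the first methyl, a 110-fold higher number from compound 1 to compound 2 (2.05 log units; beyond the scatter), does not stop once that carbon carries one methyl. Among compounds 1, 2 and 4, which differ only at this carbon, each added methyl gives a large step in the same direction, and none of the three goes against this order. Nothing measured here gives a reason for either rise.

Going by these compounds, whether an ethyl group, a longer chain or a fluorine on this carbon would follow the same course remains open. Also open, on these data alone, is whether the methyl steps keep their size with chloro in place of methyl on the aromatic carbon.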